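Fluoro in place of nitro: compound 1 to compound 4

The source may hold more compounds than are shown below. What is called first, only, known or untested is meant among the compounds shown, and "the series" means these compounds.

Measured in an ADME assay on Vero cells (Chlorocebus sabaeus) for cytotoxicity, read by MTT assay, with a stated time of 72 h; a higher number here means a weaker inhibitor, a lower number a stronger inhibitor:
- compound 1 `Cn1cc([N+](=O)[O-])cc1C(=O)NNC(=S)Nc1ccc([N+](=O)[O-])cc1`: 395000 nM
- compound 2 `COc1ccc(OC)c(NC(=O)NNC(=O)c2cc([N+](=O)[O-])c[nH]2)c1`: 333000 nM
- compound 3 `O=C(NNC(=S)NCc1ccccc1)c1cc([N+](=O)[O-])c[nH]1`: 397000 nM

Compound 1 stands within the scatter of both compound 2 and compound 3, so it holds no distinct place among the three. Compound 4 `Cn1cc([N+](=O)[O-])cc1C(=O)NNC(=S)Nc1ccc(F)cc1` carries fluoro in place of nitro on an aromatic carbon, para to a large group (fluoro in place of nitro on an aromatic carbon). Within the data shown here, no two measured compounds differ in one place, so no measured step speaks to this change. The expectation rests only on the close agreement of compound 1 at 395000 nM, compound 2 at 333000 nM and compound 3 at 397000 nM. In this assay, the expected step of a 1.1-fold lower number from compound 1 to compound 4 (0.05 log units; within the scatter) stays within the scatter, with no direction favoured. For compound 4 the estimated value is 350000 nM, with an expected range of 180000 nM to 600000 nM.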

Compound 4, half-maximal inhibitory concentration: 662000 nM
The estimate for compound 4 lay 1.9-fold (0.28 log units) below the measured number, outside the stated range (above it).
By their numbers in this assay, from the lowest: compounds 2, 1, 3 and 4 (each within the scatter of the next).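

Among these compounds, this is the first one-place step: fluoro in place of nitro on an aromatic carbon, para to a large group, gives a 1.7-fold higher number from compound 1 to compound 4 (0.22 log units; within the scatter) in this assay. Compound 1 and compound 4 thus stand within the scatter of each other, so the nitro at this position is not needed for a reading in this range. Nothing on hand explains the step.

From the compounds shown here alone, what an amine or a carboxylic acid on the same carbon would give stays open. So does whether this change reads the same on another core.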